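Solubility of the shared core with varied aminopyridine substituents

The compounds below may be only part of what the source reports. "The series", "measured", "known", "first", "only" and "open" are said of these compounds alone.

Compound 1 `CC1(C)C(=O)N(c2ccc(SC(F)(F)F)cc2)C(=O)N1Cc1ccnc(N2CCCCC2)c1` is the reference point. In a physicochemical assay for solubility, read by nephelometry (on this read-out higher numbers stand for higher solubility and lower numbers for lower solubility), compound 1 gives only a limit of the assay, < 0.024 ug/mL. Within the data shown here, compound 2 `CN1CCN(c2cc(CN3C(=O)N(c4ccc(SC(F)(F)F)cc4)C(=O)C3(C)C)ccn2)CC1` is the one member of the trio with a number in this assay: compound 2 gives 0.159 ug/mL. Compound 3 `CC1(C)C(=O)N(c2ccc(SC(F)(F)F)cc2)C(=O)N1Cc1ccnc(NCc2ccccc2)c1` again returns only a limit: in this assay compound 3 gives < 0.026 ug/mL. Two of the three values therefore sit at the floor of the assay, the limit at which compound 1 sits the limit of < 0.024 ug/mL in this assay, at which 1 of the 3 values shown sits, and the limit at which compound 3 sits (the limit of < 0.026 ug/mL in this assay, at which 1 of the 3 values shown sits).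

The measured steps: an at least 6.6-fold higher number from compound 1 to compound 2 (0.82 log units; beyond the scatter) and, in the reverse sense, an at least 6.1-fold lower number from compound 2 to compound 3 (0.78 log units; beyond the scatter). The step that the two limits leave unreadable from compound 1 to compound 3.

Compound 4 `CC(C)Nc1cc(CN2C(=O)N(c3ccc(SC(F)(F)F)cc3)C(=O)C2(C)C)ccn1` differs from compound 1 by isopropylamino in place of piperidin-1-yl on an aromatic carbon. Among the measured compounds shown here, no measured step covers this change. The nearest comparison is compound 3, whose benzylamino group also carries the donor and acceptor counted above, yet compound 3 stayed at the limit. An isopropylamino group is smaller than benzylamino, so a modest rise over compound 1 is expected, though not up to the number of compound 2; the expected step is an at least 1.8-fold higher number from compound 1 to compound 4 (0.27 log units; that floor lies within the scatter). Compound 4 is accordingly expected to give about 0.045 ug/mL, within 0.012 ug/mL to 0.18 ug/mL, with a real chance that only a limit is reported.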

Compound 4, solubility: < 0.023 ug/mL
Compound 4 gave a limit, no number (the forecaster's own chance of this, stated with the estimate: 50%); middle value at least 1.9-fold (0.29 log units) from the limit.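

Compound 4 also stands at a limit in this assay, not at a number: the limit of < 0.023 ug/mL in this assay, at which 1 of the 4 values shown sits.

Isopropylamino drops the ring of piperidin-1-yl and brings a hydrogen-bond donor, yet this exchange on the aromatic carbon next to the ring nitrogen still returns no number, so the steps from compound 1 and from compound 3 to compound 4 cannot be read. Among these compounds, the one readable step in this assay is an at least 6.9-fold lower number from compound 2 to compound 4 (0.83 log units; beyond the scatter), which leaves 4-methylpiperazin-1-yl as the only group of the four at this position with a measured number.

From the compounds shown here alone, what in 4-methylpiperazin-1-yl goes with that number stays open, since compound 2 differs from compound 1 in both the added ring nitrogen and its methyl. Piperazin-1-yl, morpholin-4-yl or an open-chain group such as 2-(dimethylamino)ethylamino at this position would show whether a number appears without the methyl, without the second ring nitrogen or without the ring.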